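A few compounds are considered here, and "the series" means these few. Any claim that something is new, unique, unknown or untested is made for them only; others in the source may bear on it.

Compound 1 `CC[C@]1(C(=O)O)CC[C@H](C(=O)N2CC[C@](c3ccc(C(F)(C(F)(F)F)C(F)(F)F)cc3)(S(=O)(=O)c3ccc(F)cc3)C2)CC1`: "not determined" (no result reported)
Compound 2 `O=C([C@H]1CC[C@H](c2nnn[nH]2)CC1)N1CC[C@](c2ccc(C(F)(C(F)(F)F)C(F)(F)F)cc2)(S(=O)(=O)c2ccc(F)cc2)C1`: 73%
Compound 3 `CS(=O)(=O)C1CCC(C(=O)N2CC[C@](c3ccc(C(F)(C(F)(F)F)C(F)(F)F)cc3)(S(=O)(=O)c3ccc(F)cc3)C2)CC1`: 69%; "not determined" (no result reported) (2 entries)

All three readings come from an ADME assay on microsomes from liver (Mus musculus) for metabolic stability, with a stated time of 10 min; a lower number here means that less of the compound is left, a higher number that more of the compound is left. For the measured compounds named here, compound 2, at 73%, holds the only single number in this small set, and its two neighbours offer little to rank it against. Compound 1 has no result. Going by the values given here, the record for compound 3 is the several entries of compound 3 in this assay, 69%; "not determined" (no result reported) (2 entries), and its one number lies within the scatter of compound 2.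

The next compound is compound 4 `O=C(N1CC[C@](c2ccc(C(F)(C(F)(F)F)C(F)(F)F)cc2)(S(=O)(=O)c2ccc(F)cc2)C1)C1(O)CCS(=O)(=O)CC1`. It keeps the shared core and places 4-hydroxy-1,1-dioxothian-4-yl in place of 4-(1H-tetrazol-5-yl)cyclohexyl on a carbonyl carbon whose other neighbours are an amide-type nitrogen in a ring: 4-hydroxy-1,1-dioxothian-4-yl in place of 4-(1H-tetrazol-5-yl)cyclohexyl on a carbonyl carbon.

Among the compounds with values here, no measured pair differs in one place only, so the size of such a change cannot be read from the data. Within the data shown here, the only anchors are compound 2 at 73% and compound 3 at 69%; "not determined" (no result reported) (2 entries), and these two values sit within the scatter of each other. On that basis no step beyond the scatter is expected in this assay, and no direction is favoured. The expected change is a number 2 percentage points higher from compound 2 to compound 4 (within the scatter).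

For compound 4 the estimate is 75%, with an expected range of 58% to 90%.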

Compound 4, percent of the compound remaining: 90%
For compound 4 the middle estimate is 15 percentage points below the measured one; measured number inside the range.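

In this assay the place on a carbonyl carbon whose other neighbours are an amide-type nitrogen in a ring now shows that it can move the read-out: 4-hydroxy-1,1-dioxothian-4-yl in place of 4-(1H-tetrazol-5-yl)cyclohexyl gives a number 17 percentage points higher from compound 2 to compound 4 (beyond the scatter). For the compounds shown here, the earlier compounds offered no step beyond the scatter, so this is the first sign that the group at this place matters while the shared core stays the same. The two groups have equal hydrogen-bond donor and acceptor counts, so those counts do not track the step, and no measurement shown accounts for it.

Going by these compounds, the entering group brings the hydroxy group and the ring sulfone together, so the part that carries the step stays open; an amine in place of the hydroxy group on the same ring carbon would begin to separate the two. Going by these compounds alone, whether a step of this size holds for other groups at this place also stays open, since compound 2 and compound 4 form the only readable pair in this assay.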